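The compounds below may be only part of what the source reports. "The series", "measured", "known", "first", "only" and "open" are said of these compounds alone.

Two compounds of this series have been measured in a functional assay on HeLa cells (Homo sapiens) for antiproliferative activity, read by CCK-8 assay, with a stated time of 72 h; a lower number here means a stronger inhibitor, a higher number a weaker inhibitor:

Compound 1 `O=C(Nc1cccc(-c2oc3cc(-c4ccc(F)cc4)ccc3c(=O)c2O)c1)c1ccc(F)cc1`: 5350 nM
Compound 2 `Cc1cc(C)cc(C(=O)Nc2cccc(-c3oc4cc(-c5ccc(F)cc5)ccc4c(=O)c3O)c2)c1`: 5540 nM

Compound 1 has the lowest of the two numbers, but the only step that has been measured, a 1.0-fold higher number from compound 1 to compound 2 (0.02 log units; within the scatter), is within the scatter, so the two compounds cannot be told apart on the evidence shown. Compound 3 `O=C(Nc1cccc(-c2oc3cc(-c4ccc(F)cc4)ccc3c(=O)c2O)c1)c1ccc([N+](=O)[O-])cc1` is not yet measured. It differs from compound 1 in one place: nitro in place of fluoro on an aromatic carbon. Among the compounds with values here, no measured step touches the position in question in this way; the one known step changed the whole aryl group on the carbonyl carbon and left the number where it was. On that basis the expectation for compound 3 in this assay is a change of about a 1.1-fold lower number from compound 1 to compound 3 (0.03 log units; within the scatter), that is, nothing beyond the scatter, with the number estimated at 5000 nM and expected to fall between 2000 nM and 13000 nM.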

Compound 3, half-maximal inhibitory concentration: 12300 nM
Compound 3: the middle estimate sits 2.5-fold (0.39 log units) below what was measured; the range from low to high includes it.
By their numbers in this assay, from the lowest: compounds 1 and 2 (each within the scatter of the next); then compound 3.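

In this assay, within the data shown here, the aryl group on the carbonyl carbon had so far looked indifferent, but a single replacement on the aromatic carbon para to a large group does move the number: nitro in place of fluoro gives a 2.3-fold higher number from compound 1 to compound 3 (0.36 log units; beyond the scatter), and 4-nitrophenyl in place of 3,5-dimethylphenyl gives a 2.2-fold higher number from compound 2 to compound 3 (0.35 log units; beyond the scatter). Both steps are modest, but both lie beyond the scatter and both run towards a weaker inhibitor, so this part of the molecule is not silent. Nothing shown accounts for the shift.

Going by these compounds, whether the loss belongs to nitro alone or would also appear with an amine, a methoxy group or a carboxylic acid on the same carbon remains open. A single nitro compound also cannot show whether any group there would give a stronger inhibitor than compound 1.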